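Swapping a styryl arm for a dimethoxyphenyl on the pyrazoline

This account rests on a few compounds, and the source may have more. Where it says the series, first, only, none or still open, it means among the compounds named here.

Measured compounds in a functional assay on UO-31 cells (Homo sapiens) for antiproliferative activity, with a stated time of 48 h; on this read-out lower numbers stand for higher toxicity in this test and higher numbers for lower toxicity in this test:
compound 1 `Cc1cc(O)c(C2=NN(c3ccc(S(N)(=O)=O)cc3)C(c3ccccc3O)C2)cc1Cl` gives 38500 nM
compound 2 `Cc1cc(O)c(C2=NN(c3ccc(S(N)(=O)=O)cc3)C(c3ccccc3Cl)C2)cc1Cl` gives 48000 nM
compound 3 `Cc1cc(O)c(C2=NN(c3ccc(S(N)(=O)=O)cc3)C(/C=C/c3ccccc3)C2)cc1Cl` gives 79900 nM

Compound 3 shows the highest number of the three. Its nearest neighbour is compound 2, with a 1.7-fold higher number from compound 2 to compound 3 (0.22 log units; within the scatter), a step that stays within the scatter; the step of a 2.1-fold higher number from compound 1 to compound 3 (0.32 log units; beyond the scatter) is a modest one beyond it. Compound 4 `COc1ccc(C2CC(c3cc(Cl)c(C)cc3O)=NN2c2ccc(S(N)(=O)=O)cc2)cc1OC` is not yet measured. It differs from compound 3 in one place: 3,4-dimethoxyphenyl in place of 2-phenylethenyl on a saturated ring carbon.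

The two steps that bear on this change are those that put the 2-phenylethenyl group onto the same saturated ring carbon in place of a substituted phenyl, a 2.1-fold higher number from compound 1 to compound 3 (0.32 log units; beyond the scatter) and a 1.7-fold higher number from compound 2 to compound 3 (0.22 log units; within the scatter). Both moved the number upward, one of them beyond the scatter. Compound 4 reverses that kind of change, returning an aromatic ring to that carbon, so a step back toward the numbers of compound 1 and compound 2 is expected in this assay, though it may stay within the scatter. For compound 4 the expected step is a 1.6-fold lower number from compound 3 to compound 4 (0.20 log units; within the scatter). Compound 4 is therefore estimated at 50000 nM, with a range from 25000 nM to 100000 nM.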

Compound 4, concentration lethal to 50% of the cells: > 100000 nM
Compound 4: only a limit was reported (the forecaster's own chance of this, stated with the estimate: 10%); middle value at least 2.0-fold (0.30 log units) away from the limit.
By their numbers in this assay, from the lowest: compounds 1, 2 and 3 (each within the scatter of the next, the first and the last beyond it). At a limit, above all of these: compound 4.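

In this assay compound 4 gave only a limit and not a number: the limit of > 100000 nM in this assay, at which 1 of the 4 values shown sits. Against the two substituted phenyl neighbours the change is readable, with an at least 2.0-fold higher number from compound 2 to compound 4 (0.31 log units; beyond the scatter) and an at least 2.5-fold higher number from compound 1 to compound 4 (0.41 log units; beyond the scatter), so an aromatic ring on this saturated ring carbon does not by itself keep the number in the range of those two compounds. Against the 2-phenylethenyl group, an at least 1.2-fold higher number from compound 3 to compound 4 (0.09 log units; that floor lies within the scatter), so this comparison fixes only a floor and not the size of the change.

As far as these compounds go, the true value of compound 4 remains unknown, so its distance from all three neighbours stays open. Also open, from the compounds shown here alone, is whether an amine or a carboxylic acid on the phenyl ring at this carbon, in place of the two methoxy groups, would bring the number back down.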